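Methoxy removal on a chromone dithiocarbamate series

A few compounds are considered here, and "the series" means these few. Any claim that something is new, unique, unknown or untested is made for them only; others in the source may bear on it.

Measured compounds in a functional assay on MDA-MB-435S cells (Homo sapiens) for antiproliferative activity, read by MTT assay, with a stated time of 72 h; a lower number here means a stronger inhibitor, a higher number a weaker inhibitor:
Compound 1, `COc1ccc2oc(CSC(=S)N(C(C)C)C(C)C)cc(=O)c2c1`, gives 22100 nM.
Compound 2, `CC(C)N(C(=S)SCc1cc(=O)c2ccccc2o1)C(C)C`, returns only a limit of the assay, > 40000 nM.
Compound 3, `COc1ccc2occ(CSC(=S)N3CCCCC3)c(=O)c2c1`, gives 930 nM.

Compound 3 sits lowest among the two numbered values; the difference between its core and the core of compound 1 is not broken down here. Going by the values given here, the one step that can be read is an at least 1.8-fold higher number from compound 1 to compound 2 (0.25 log units; that floor lies within the scatter), the change being (hydrogen in place of methoxy on an aromatic carbon). On these data alone, its true size is unknown, since the value of compound 2 is the limit of > 40000 nM in this assay, at which 1 of the 3 values shown sits.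

Compound 4, `O=c1c(CSC(=S)N2CCCCC2)coc2ccccc12`, is not yet measured. It differs from compound 3 by hydrogen in place of methoxy on an aromatic carbon, the same change seen from compound 1 to compound 2. Given that step an at least 1.8-fold higher number from compound 1 to compound 2 (0.25 log units; that floor lies within the scatter), a weakening is expected, estimated as a 2.7-fold higher number from compound 3 to compound 4 (0.43 log units; beyond the scatter). For compound 4 the expected value is 2500 nM, with a range of 900 nM to 8000 nM.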

Compound 4, half-maximal inhibitory concentration: 470 nM
Estimate against measurement, compound 4: 5.3-fold (0.73 log units) above; measured number outside the range, below it.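

In this assay, hydrogen in place of methoxy on an aromatic carbon gives a 2.0-fold lower number from compound 3 to compound 4 (0.30 log units; within the scatter), so on this core the change does not separate the two compounds. Set beside the earlier step, the change does not carry over as one fixed step from one core to the other: the same change on two cores in this assay, an at least 1.8-fold higher number (0.25 log units; that floor lies within the scatter) from compound 1 to compound 2 and a 2.0-fold lower number (0.30 log units; within the scatter) from compound 3 to compound 4, at least 3.5-fold (0.55 log units) apart, beyond the scatter of two such steps. On these data alone, compound 2 stands only at a limit of the assay, so the size of the earlier step and of the full gap stays unknown: the limit of > 40000 nM in this assay, at which 1 of the 4 values shown sits.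

Which of the differences between the two cores sets this gap remains open, as no pair here separates them. Also open, as far as these compounds go, is how a hydroxyl group or a chlorine atom in the same place would compare with methoxy on either core.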